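Bromo for chloro on the sulfonyl aromatic ring

The compounds below may be only part of what the source reports. "The series", "measured", "known", "first", "only" and "open" are said of these compounds alone.

Four compounds share one scaffold and differ in two places. Compound 1 `O=C1/C(=C/c2cccc(F)c2)CN(S(=O)(=O)c2ccc(Cl)cc2)C/C1=C\c1cccc(F)c1` carries a (4-chlorophenyl)sulfonyl group; in a functional assay on SMMC-7721 cells (Homo sapiens) for cytotoxicity, read by MTT assay, with a stated time of 24 h (a higher number here means a weaker inhibitor, a lower number a stronger inhibitor), compound 1 gives 7800 nM. Compound 2 `O=C1/C(=C/c2cccc(F)c2)CN(S(=O)(=O)c2ccc(Br)cc2)C/C1=C\c1cccc(F)c1` differs from compound 1 only by the change (bromo in place of chloro on an aromatic carbon), and in this assay compound 2 gives 11700 nM. That change made the step of a 1.5-fold higher number from compound 1 to compound 2 (0.18 log units; within the scatter). Compound 3 `O=C1/C(=C/c2ccc(F)cc2)CN(S(=O)(=O)c2ccc(Cl)cc2)C/C1=C\c1ccc(F)cc1` has the same atoms as compound 1 joined differently; the difference between the two cores is not broken down here. In this assay compound 3 gives 7000 nM, a value within the scatter of compound 1 and of compound 2, so no order among the three measured compounds can be read. Going by the values given here, compound 4 `O=C1/C(=C/c2ccc(F)cc2)CN(S(=O)(=O)c2ccc(Br)cc2)C/C1=C\c1ccc(F)cc1` has not been measured; it differs from compound 3 by bromo in place of chloro on an aromatic carbon, which is the same change as the one from compound 1 to compound 2, down to the place where it sits. With one prior instance of the change, itself within the scatter, the expectation for compound 4 rests on that instance alone: compound 4 is expected to lie a step of a 1.4-fold higher number from compound 3 to compound 4 (0.15 log units; within the scatter) from compound 3, because the same change gave a 1.5-fold higher number from compound 1 to compound 2 (0.18 log units; within the scatter). Compound 4 is expected to give 10000 nM in this assay, with a likely range from 5000 nM to 20000 nM. A large move in either direction is not expected.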

Compound 4, half-maximal inhibitory concentration: 11500 nM
Compound 4: the middle estimate sits 1.2-fold (0.06 log units) below what was measured, and the stated range covers the measured number.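

In this assay, going by these compounds alone, bromo in place of chloro on the sulfonyl aromatic ring gives a 1.6-fold higher number from compound 3 to compound 4 (0.22 log units; within the scatter), and the change carries from one core to the other with no readable difference between the two instances: the same change on two cores in this assay, a 1.5-fold higher number (0.18 log units; within the scatter) from compound 1 to compound 2 and a 1.6-fold higher number (0.22 log units; within the scatter) from compound 3 to compound 4, 1.1-fold (0.04 log units) apart, within the scatter of two such steps Each step lies within the scatter, so the agreement shows only that the swap leaves the number unresolved on both cores, and no direction for bromo against chloro can be claimed. Two pairs on two closely related cores say nothing about this change on any other core in the series, nor about how the 4-chlorophenyl and 4-bromophenyl groups would compare in another assay.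

The compounds shown carry only chloro or bromo at this place on the ring, para to a large group, so it remains open whether an amine, a methoxy group or a carboxylic acid there would move the number beyond the scatter. The fluoro groups on the other two aromatic rings also appear in only two arrangements, which leaves open what a nitrile or a hydroxyl group on those rings would do in this assay.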